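Phenyl in Place of Acetyl: Expected Half-Life Step

The compounds below may be only part of what the source reports. "The series", "measured", "known", "first", "only" and "open" are said of these compounds alone.

Compound 1, `N=C(N)SCCCOc1oc(=O)c2cc(NC(=O)CCc3ccccc3)ccc2c1Cl`: 1.1 h
Compound 2, `CC(=O)CCC(=O)Nc1ccc2c(Cl)c(OCCSC(=N)N)oc(=O)c2c1`: 0.467 h
Compound 3, `C[C@H](NC(=O)OC(C)(C)C)C(=O)N[C@@H](C)C(=O)Nc1ccc2c(Cl)c(OCCSC(=N)N)oc(=O)c2c1`: 0.667 h

All three were run in an ADME assay for pharmacokinetics; a lower number here means that the compound disappears faster, a higher number that the compound lasts longer. Compound 2 gives the lowest of the three numbers; compound 3 lies within the scatter of it, while compound 1 stands beyond the scatter above it. Compound 4, `N=C(N)SCCOc1oc(=O)c2cc(NC(=O)CCc3ccccc3)ccc2c1Cl`, awaits measurement. It differs from compound 2 in one place: phenyl in place of acetyl on a saturated chain carbon, two bonds along the chain from a carbonyl carbon. Within the data shown here, no measured pair shares this change, so the expectation rests on the numbers alone. Because compound 1, which also bears a phenethylcarbonyl, gives 1.1 h, compound 4 is expected to move upward by a 1.9-fold higher number from compound 2 to compound 4 (0.28 log units; within the scatter), a step beyond the scatter. The estimate for compound 4 is 0.9 h, with a range from 0.45 h to 1.8 h.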

Compound 4, half-life: 0.65 h
Compound 4: middle estimate off by 1.4-fold (0.14 log units), on the high side, within the range that was stated.
By their numbers in this assay, from the lowest: compounds 2, 4, 3 and 1 (each within the scatter of the next, the first and the last beyond it).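

In this assay, among these compounds, phenyl in place of acetyl on a saturated chain carbon, two bonds along the chain from a carbonyl carbon, gives a first reading for this change (a 1.4-fold higher number from compound 2 to compound 4 (0.14 log units; within the scatter)), and it does not separate the two groups. With phenethylcarbonyl held constant, the group of 4 heavy atoms in place of the group of 5 also stays unresolved (a 1.7-fold lower number from compound 1 to compound 4 (0.23 log units; within the scatter)). Nothing measured here explains either result.

From the compounds shown here alone, whether an amine or a carboxylic acid at this chain carbon would stand apart from phenyl or acetyl remains open. So does the reading for a longer chain in place of phenethyl.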